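Dechlorination of the benzoyl in a growth-inhibition series

The source may hold more compounds than are shown below. What is called first, only, known or untested is meant among the compounds shown, and "the series" means these compounds.

Measured so far in a functional assay on ACHN cells (Homo sapiens) for cytotoxicity, read by sulforhodamine B assay, with a stated time of 72 h; on this read-out lower numbers stand for stronger inhibition of growth and higher numbers for weaker inhibition of growth:
compound 1 `O=C(Nc1cc(C(F)(F)F)cc(C(F)(F)F)c1)C1CCc2ccccc2N1C(=O)c1cccc(Cl)c1`: 813 nM
compound 2 `O=C(Nc1ccccc1O)C1CCc2ccccc2N1C(=O)c1ccccc1Cl`: 44200 nM

Within the data shown here, compound 1 has the lower of the two numbers; compound 2 differs from it in more than one place, so no single step connects them, and their two values show only that compound 1 sits far below compound 2 in this assay, well beyond the scatter.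

Compound 3 `O=C(Nc1cc(C(F)(F)F)cc(C(F)(F)F)c1)C1CCc2ccccc2N1C(=O)c1ccccc1` is the next case and has not yet been tested. Relative to compound 1 the change is hydrogen in place of chloro on an aromatic carbon. It is a small edit at the periphery of the benzoyl; nothing within the measured pair speaks to what a chloro on that ring contributes, since compound 2 carries its chloro elsewhere together with a different anilide.

Among the measured compounds shown here, with no comparable step to lean on, the expectation is a modest weakening, possibly none beyond the scatter, and the step from compound 1 is estimated at a 2.0-fold higher number from compound 1 to compound 3 (0.29 log units; within the scatter). Compound 3 is therefore expected to give about 1600 nM in this assay, with a plausible range from 500 nM to 5000 nM.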

Compound 3, concentration for 50% growth inhibition: 2920 nM
Beside the measured number, compound 3's estimate is 1.8-fold (0.26 log units) below it; the range from low to high includes it.
By their numbers in this assay, from the lowest: compound 1; then compound 3; then compound 2.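

In this assay, among these compounds, the loss of the chloro gives a 3.6-fold higher number from compound 1 to compound 3 (0.56 log units; beyond the scatter) and this is the first step that can be read at a single place, as the earlier pair differed in more than one. It shows that the 3-chlorophenyl to phenyl change alone moves the number beyond the scatter, although only one chlorine atom leaves and a hydrogen enters, with no ring, hydrogen-bond donor, hydrogen-bond acceptor or net charge involved. The size of the step is modest, so the chloro on this aromatic carbon adds to growth inhibition in the core of compound 1 but does not account for all of it, and no measurement at hand bears on the cause of the step.

From the compounds shown here alone, whether chloro is special here or other substituents on the same aromatic carbon serve as well remains open, and a fluoro, a methyl, a methoxy, an amine or a carboxylic acid at that place would separate these readings. Also open is whether the step holds with a different anilide, since the compounds shown read this change only with the anilide of compound 1.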